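Cytotoxicity of the amine-chain variants on MT2 cells

The compounds below may be only part of what the source reports. "The series", "measured", "known", "first", "only" and "open" are said of these compounds alone.

Compound 1 `Cc1ccc(-c2c3c(nc(C)c2C(OC(C)(C)C)C(=O)O)CCN(CCCC2CCCC2)C3)cc1` was tested in an ADME assay on MT2 cells (Homo sapiens) for cytotoxicity, read by XTT assay, with a stated time of 4 days (on this read-out higher numbers stand for lower toxicity in this test and lower numbers for higher toxicity in this test), and the result is a limit rather than a number: compound 1 gives > 40000 nM. Compound 2 `Cc1nc2c(c(-c3cc(F)c4c(c3C)CCCO4)c1[C@H](OC(C)(C)C)C(=O)O)CN(CCCc1ccc(F)cc1)CC2` stands at the same limit in this assay, where compound 2 gives > 40000 nM. Neither value is a number, so no ordering between compound 1 and compound 2 can be drawn; both sit at the limit (the limit of > 40000 nM in this assay, at which 2 of the 2 values shown sit), and nothing in the data places compound 1 above or below the other compound.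

Compound 3 `CCCCCN1CCc2nc(C)c(C(OC(C)(C)C)C(=O)O)c(-c3ccc(C)cc3)c2C1` has not yet been run in this assay. Relative to compound 1, compound 3 carries ethyl in place of cyclopentyl on a saturated chain carbon, three bonds along the chain from an amine nitrogen in a ring; seen one bond further out, the change reads cyclopentylmethyl to propyl, the chain on the ring amine nitrogen becoming shorter and losing its ring.

Going by the values given here, no step between two measured compounds is available to calibrate the effect of this change. The expectation for compound 3 is that the step that the limit leaves unreadable from compound 1 to compound 3 stays within the scatter, since compound 1 already gives > 40000 nM at the limit. Compound 3 is therefore expected to give about 60000 nM in this assay, within a range of 25000 nM to 150000 nM, most likely reported again as a limit.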

Compound 3, half-maximal cytotoxic concentration: > 40000 nM
Compound 3: no number, only a limit; the forecaster's own chance of this, stated with the estimate: 85%; the middle value lies beyond the limit too.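

Compound 3 gives > 40000 nM, a limit and not a number. Going by these compounds alone, compound 1 also stands at a limit, and no step from compound 1 to compound 3 can be read. The compounds shown leave open where any half-maximal cytotoxic concentration lies, and whether going from cyclopentylmethyl to propyl changes it at all: the limit of > 40000 nM in this assay, at which 3 of the 3 values shown sit.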